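The source may report more compounds than this note shows. Statements on the series, on what has been measured and on what is new or still open speak of the compounds shown alone.

Measured so far in an ADME assay on Vero cells (Chlorocebus sabaeus) for cytotoxicity, read by fluorescence, with a stated time of 4 days; a lower number here means a stronger inhibitor, a higher number a weaker inhibitor:
- compound 1 (`COC1=C(CC(C)(C)CNC(=O)c2ccc3ccccc3c2)C(=O)c2ccccc2C1=O`) gives 36000 nM
- compound 2 (`COC1=C(CC(C)(C)CNC(=O)c2ccc3ccccc3c2OC)C(=O)c2ccccc2C1=O`) gives 60600 nM

Compound 1 has only compound 2 to be compared with, and the two values lie within the scatter of each other, so neither stands apart. The next compound is compound 3 (`COC1=C(CC(C)(C)CNC(=O)c2cc(OC)ccc2OC)C(=O)c2ccccc2C1=O`), which carries 2,5-dimethoxyphenyl in place of naphthalen-2-yl on a carbonyl carbon. For the measured compounds named here, the only measured step that bears on this change is methoxy in place of hydrogen on an aromatic carbon (a 1.7-fold higher number from compound 1 to compound 2 (0.23 log units; within the scatter)), and it stays within the scatter. It covers the entry of a methoxy group only. Going by the values given here, no measured compound shows the loss of the naphthalen-2-yl group, so that part of the change remains untested. On this evidence, no step beyond the scatter is expected in this assay and no firm direction can be given. The expected step is small (a 1.3-fold higher number from compound 1 to compound 3 (0.10 log units; within the scatter)). Compound 3 is expected at 45000 nM (estimated range 18000 nM to 110000 nM).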

Compound 3, half-maximal inhibitory concentration: 36200 nM
Beside the measured number, compound 3's estimate is 1.2-fold (0.09 log units) above it; measured number inside the range.
By their numbers in this assay, from the lowest: compounds 1, 3 and 2 (each within the scatter of the next).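

In this assay, 2,5-dimethoxyphenyl in place of naphthalen-2-yl on a carbonyl carbon gives a 1.0-fold higher number from compound 1 to compound 3 (0.00 log units; within the scatter). For the compounds shown here, compound 2 kept naphthalen-2-yl and showed only the entry of a methoxy group, whereas this step is the first in which that group leaves, with 2 hydrogen-bond acceptors entering and one six-membered aromatic ring of carbon only in place of 2 such rings, and it still stays within the scatter. So at this position on the carbonyl carbon, the shown exchange of one aromatic group for another of 10 heavy atoms leaves the number unresolved from that of compound 1, and no evidence on the properties of either group bears on this result.

The compounds shown leave open what each methoxy group of 2,5-dimethoxyphenyl contributes, which an unsubstituted phenyl or a single methoxyphenyl would help to separate. They also leave open whether a group of a different kind on the carbonyl carbon, such as a cyclohexyl ring, or an aromatic ring carrying an amine or a carboxylic acid, would give a step beyond the scatter.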